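Amide variation on the acrylamide series: compound 4

This account rests on a few compounds, and the source may have more. Where it says the series, first, only, none or still open, it means among the compounds named here.

For the measured compounds named here, in an assay on a protein complex for inhibition of CDK8/Cyclin C (Homo sapiens), with a stated time of 1 h (on this read-out lower numbers stand for stronger inhibition and higher numbers for weaker inhibition), the three measured members sit close together. Compound 1 `CN1CCN(C(=O)/C=C/c2ccncc2-c2ccc3ccccc3c2)CC1` gives 43.6 nM; compound 2 `CCOC(=O)/C=C/c1ccncc1-c1ccc2ccccc2c1` gives 53.3 nM; compound 3 `COC1CN(C(=O)/C=C/c2ccncc2-c2ccc3ccccc3c2)C1` gives 42.8 nM. The steps between them, a 1.2-fold higher number from compound 1 to compound 2 (0.09 log units; within the scatter), a 1.0-fold lower number from compound 1 to compound 3 (0.01 log units; within the scatter) and a 1.2-fold lower number from compound 2 to compound 3 (0.10 log units; within the scatter), are all within the scatter, so compound 3 has the smallest of the three figures without being separated from either neighbour.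

The next compound, compound 4 `O=C(/C=C/c1ccncc1-c1ccc2ccccc2c1)N1CCOCC1`, differs from compound 3 in one place: morpholin-4-yl in place of 3-methoxyazetidin-1-yl on a carbonyl carbon. The change again touches only the group on the carbonyl carbon, the same place varied in the three measured steps, where a cyclic amine, an ester and a second cyclic amine gave figures that did not move beyond the scatter. Going by the values given here, no measured step bears on the morpholin-4-yl group itself, so the expectation rests on that pattern alone.

Compound 4 is therefore expected to stay within the scatter of compound 3, a step of a 1.1-fold higher number from compound 3 to compound 4 (0.02 log units; within the scatter). The estimate for compound 4 in this assay is 45 nM, with a range from 22 nM to 95 nM.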

Compound 4, half-maximal inhibitory concentration: 60.3 nM
Beside the measured number, compound 4's estimate is 1.3-fold (0.13 log units) below it; low and high end bracket the measured number.
By their numbers in this assay, from the lowest: compounds 3, 1, 2 and 4 (each within the scatter of the next).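

In this assay the morpholin-4-yl group brings a six-membered ring with two hetero atoms to the carbonyl carbon, and all three new steps stay within the scatter: a 1.4-fold higher number from compound 3 to compound 4 (0.15 log units; within the scatter) and a 1.4-fold higher number from compound 1 to compound 4 (0.14 log units; within the scatter) and also a 1.1-fold higher number from compound 2 to compound 4 (0.05 log units; within the scatter). The same heavy atoms joined differently, as 3-methoxyazetidin-1-yl or morpholin-4-yl, give no separable difference, so ring size and the arrangement of the ring oxygen show no effect at this place across these compounds. No measurement at hand bears on why these groups read alike.

As far as these compounds go, whether any group on this carbonyl carbon can move the number beyond the scatter remains open, since only cyclic amines and ethoxy appear there. A carboxylic acid, or a secondary amide that keeps the amide hydrogen, would test this position further.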